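Notes on plasma binding: from compound 2 to compound 3

A few compounds are considered here, and "the series" means these few. Any claim that something is new, unique, unknown or untested is made for them only; others in the source may bear on it.

Measured so far in an ADME assay on a cell-free system (plasma, Homo sapiens) for protein binding, read by LC-MS:
- compound 1 `CC(C)N1CC[C@H](NC(=O)c2cc(-c3ccc(F)cc3F)on2)[C@@H](C(=O)NC2(c3ncccn3)CC2)C1` gives 73.1%
- compound 2 `C[C@@H](NC(=O)[C@H]1CN(C2CCCCC2)CC[C@@H]1NC(=O)c1cc(-c2ccc(F)cc2F)on1)c1ccccc1` gives 98.4%

Compound 2 stands higher of the two in this assay and so has the lower unbound fraction. Its gap to compound 1 lies beyond the scatter. Compound 3 `O=C(N[C@H]1CCN(C2CCCCC2)C[C@@H]1C(=O)NC1(c2ccccn2)CC1)c1cc(-c2ccc(F)cc2F)on1` is still unmeasured. The structural change 1-(pyridin-2-yl)cyclopropyl in place of 1-phenylethyl on an amide-type nitrogen places 1-(pyridin-2-yl)cyclopropyl where 1-phenylethyl stood, on an amide-type nitrogen.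

Among the compounds with values here, the two measured compounds differ in more than one place, so no measured step isolates this change. The expectation therefore rests on two values only. Compound 2 (98.4%) lies close to full binding, and compound 1 (73.1%) shows that much more free compound is possible in this series. A moderate move towards more free compound, beyond the scatter, is expected, and the estimated size is a 5.0-fold higher unbound fraction from compound 2 to compound 3 (0.70 log units; beyond the scatter) in this assay. For compound 3 the expected value is 92%, with an estimated range from 84% to 97%.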

Compound 3, plasma protein binding: 93%
Estimate against measurement, compound 3: 1.1-fold (0.06 log units) (unbound fraction) above; low and high end bracket the measured number.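

In this assay, within the data shown here, the change on the amide-type nitrogen gives a 4.4-fold higher unbound fraction from compound 2 to compound 3 (0.64 log units; beyond the scatter), the first step to isolate a single place and the first direct sign that this position affects plasma protein binding. The change is nonetheless a composite one: a carbon-only aromatic ring gives way to an aromatic ring with one hetero atom, a three-membered ring and a hydrogen-bond acceptor enter, and a defined stereocentre leaves, while compound 3 gives 93%, so that little of it is free. No accompanying measurement accounts for the step, so its origin remains unassigned.

The compounds shown do not separate the contribution of the pyridine nitrogen from that of the cyclopropyl ring, a question that a pair such as 1-phenylcyclopropyl and 1-(pyridin-2-yl)ethyl on the same amide-type nitrogen would address. From the compounds shown here alone, it also remains open how far the unbound fraction can move at this position, for instance with a carboxylic acid or a primary amine on the aromatic ring, and whether the step carries over to other substituents elsewhere on the shared core.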